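Swapping an Ester Methyl for a Dimethylaminophenyl Ring

The compounds below may be only part of what the source reports. "The series", "measured", "known", "first", "only" and "open" are said of these compounds alone.

Two related compounds built on a shared core have been tested in an in vitro ADME assay on a cell-free system (plasma, Homo sapiens) for metabolic stability; a lower number here means that the compound disappears faster, a higher number that the compound lasts longer. Compound 2 `CC(=O)OCC1=C(C(=O)O)N2C(=O)[C@@H](NC(=O)CSc3cc(Cl)ccc3Cl)C2SC1` gives about 4.17 h. For the measured compounds named here, this is the only plain number available so far, since the other result is a limit of the assay rather than a number. Compound 1 `O=C(CSc1cc(Cl)ccc1Cl)N[C@@H]1C(=O)N2C(C(=O)O)=C(COC(=O)c3ccccc3)CSC12` carries phenyl where compound 2 carries methyl on a carbonyl carbon. In this assay compound 1 gives > 10 h, which is a limit of the assay. The step of an at least 2.3-fold lower number from compound 1 to compound 2 (0.37 log units; beyond the scatter) therefore can only be read as at least that large because of the limit of > 10 h in this assay, at which 1 of the 2 values shown sits.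

Compound 3 `CN(C)c1ccc(C(=O)OCC2=C(C(=O)O)N3C(=O)[C@@H](NC(=O)CSc4cc(Cl)ccc4Cl)C3SC2)cc1` differs from compound 2 by 4-(dimethylamino)phenyl in place of methyl on a carbonyl carbon. Going by the values given here, the only measured step that bears on this change is an at least 2.3-fold lower number from compound 1 to compound 2 (0.37 log units; beyond the scatter), which runs in the opposite direction, from an aryl group back to methyl. Reversing that step, compound 3 is expected to move upward relative to compound 2 by a 2.4-fold higher number from compound 2 to compound 3 (0.38 log units; beyond the scatter), quite possibly again past the upper limit of the assay. The estimate for compound 3 in this assay is 10 h, within a range from 5 h to 24 h.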

Compound 3, half-life: > 10 h
Compound 3 gave a limit, no number; the forecaster's own chance of this, stated with the estimate: 50%; the middle value lies on the limit itself.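

Compound 3 shows that the rise seen with phenyl on this carbonyl carbon is not tied to the plain phenyl ring: 4-(dimethylamino)phenyl in place of methyl gives an at least 2.3-fold higher number from compound 2 to compound 3 (0.37 log units; beyond the scatter) in this assay. So two different aromatic rings at this place, in compound 1 and compound 3, both stand apart from the methyl of compound 2, and the true size of the change may be larger than the printed step because the results for the two ring compounds are capped: the limit of > 10 h in this assay, at which 2 of the 3 values shown sit. The step from compound 1 to compound 3, which adds dimethylamino on an aromatic carbon, cannot be read, as both results are limits, so nothing can be said about what the dimethylamino group itself does.

The compounds shown leave open how much longer either ring compound lasts in plasma, and whether the dimethylamino group makes any difference to that. They also leave open whether an aromatic ring is needed at all, since a non-aromatic group on the same carbonyl carbon, such as cyclohexyl or a longer chain like butyl, would test this directly.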